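The source may hold more compounds than are shown below. What is called first, only, known or untested is meant among the compounds shown, and "the series" means these compounds.

Measured in a functional assay on SK-MEL-28 cells (Homo sapiens) for cytotoxicity, read by CCK-8 assay, with a stated time of 24 h; on this read-out higher numbers stand for weaker inhibition and lower numbers for stronger inhibition:
Compound 1 `COc1ccccc1Oc1c(N)nc(-c2ccc(F)cc2)nc1Cl` gives 31900 nM (chloro, 4-fluorophenyl)
Compound 2 `COc1ccccc1Oc1c(N)nc(-c2cccc(I)c2)nc1Cl` gives 4660 nM (chloro, 3-iodophenyl)
Compound 3 `COc1ccccc1Oc1c(N)nc(-c2ccc(F)cc2)nc1OCCO` gives 20100 nM (2-hydroxyethoxy, 4-fluorophenyl)

Compound 3 stands clearly higher than compound 2 and cannot be told apart from compound 1, as the step (a 1.6-fold lower number from compound 1 to compound 3 (0.20 log units; within the scatter)) shows. The next structure, compound 4 `COc1ccccc1Oc1c(N)nc(-c2cccc(I)c2)nc1OCCO`, keeps the 2-hydroxyethoxy group of compound 3 and changes the other aryl group: 3-iodophenyl in place of 4-fluorophenyl on an aromatic carbon. The same exchange has been measured once, on the chloro compounds, and there it gave a modest step (a 6.8-fold lower number from compound 1 to compound 2 (0.84 log units; beyond the scatter)). The exchange of chloro for 2-hydroxyethoxy made no difference beyond the scatter, so the aryl exchange may well carry over, though a single pair is thin support. A step of similar size and the same direction is therefore expected in this assay, and it is estimated as (a 6.7-fold lower number from compound 3 to compound 4 (0.83 log units; beyond the scatter)). For compound 4 the expected value is 3000 nM, with an estimated range from 1000 nM to 9000 nM.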

Compound 4, half-maximal inhibitory concentration: 11200 nM
Compound 4: the middle estimate sits 3.7-fold (0.57 log units) below what was measured, outside the stated range (above it).
By their numbers in this assay, from the lowest: compound 2; then compounds 4, 3 and 1 (each within the scatter of the next, the first and the last beyond it).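

In this assay, the exchange of 4-fluorophenyl for 3-iodophenyl on the aromatic carbon between two ring nitrogen atoms shrinks on the 2-hydroxyethoxy core to a 1.8-fold lower number from compound 3 to compound 4 (0.25 log units; within the scatter). The step from this exchange therefore depends on whether the shared core carries chloro or 2-hydroxyethoxy: the same change on two cores in this assay, a 6.8-fold lower number (0.84 log units; beyond the scatter) from compound 1 to compound 2 and a 1.8-fold lower number (0.25 log units; within the scatter) from compound 3 to compound 4, 3.8-fold (0.58 log units) apart, beyond the scatter of two such steps. The dependence also shows from the other side, as 2-hydroxyethoxy in place of chloro now gives a step beyond the scatter on the 3-iodophenyl core, a 2.4-fold higher number from compound 2 to compound 4 (0.38 log units; beyond the scatter), which differs from the same exchange on the 4-fluorophenyl core: the same change on two cores in this assay, a 1.6-fold lower number (0.20 log units; within the scatter) from compound 1 to compound 3 and a 2.4-fold higher number (0.38 log units; beyond the scatter) from compound 2 to compound 4, 3.8-fold (0.58 log units) apart, beyond the scatter of two such steps.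

The compounds shown leave open whether the larger step on the chloro core belongs to the iodine itself, which a bromine in its place would test. They also leave open whether an amine or a longer chain in place of 2-hydroxyethoxy would give a number nearer to that of compound 2.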